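The compounds below may be only part of what the source reports. "The series", "measured", "known", "first", "only" and "open" are said of these compounds alone.

Compound 1 `Cn1cc(C(=O)N2CC3(C2)CN(c2cncc(N4C(=O)c5ccc(Cl)cc5C4(C)C)c2)C3)cn1` gives 2 nM in an assay on cells for inhibition of cytochrome P450 11B2, mitochondrial (Homo sapiens), read by HTRF; a higher number here means a weaker inhibitor, a lower number a stronger inhibitor.
Compound 2 `N#Cc1ccc2c(c1)CN(c1cccnc1)C2=O` gives 232 nM in this assay.
Compound 3 `CC(=O)N1CCC(c2cncc(N3C(=O)c4ccc(Cl)cc4C3(C)C)c2)CC1` gives 5 nM in this assay.

Compound 1 has the lowest number of the three. Compound 3 comes nearest to it, and compound 2 lies furthest away; both of these gaps are beyond the usual scatter. Compound 4 `Cc1ccncc1C(=O)N1CC2(C1)CN(c1cncc(N3C(=O)c4ccc(Cl)cc4C3(C)C)c1)C2` keeps the core of compound 1 and differs in one place: 4-methylpyridin-3-yl in place of 1-methyl-1H-pyrazol-4-yl on a carbonyl carbon. Among the compounds with values here, no measured pair shows the effect of this particular change on its own, so the expectation rests on how much of compound 1 is retained. Only a small step is expected from compound 1 to compound 4, a 1.8-fold higher number from compound 1 to compound 4 (0.24 log units; within the scatter), quite possibly within the scatter, with a slight weakening somewhat more likely than a gain. Compound 4 is therefore estimated at 3.5 nM, ranging from 1.2 nM to 12 nM.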

Compound 4, half-maximal inhibitory concentration: 14 nM
Estimate against measurement, compound 4: 4.0-fold (0.60 log units) below, and the stated range ends below it.
By their numbers in this assay, from the lowest: compound 1; then compound 3; then compound 4; then compound 2.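

In this assay the group on this carbonyl carbon clearly matters: with the rest of the molecule unchanged, 4-methylpyridin-3-yl in place of 1-methyl-1H-pyrazol-4-yl gives a 7.0-fold higher number from compound 1 to compound 4 (0.85 log units; beyond the scatter) and this step lies beyond the usual scatter. Within the data shown here, the two aromatic rings are therefore not interchangeable here, which the earlier compounds could not show. No available evidence explains this loss. Still open, as far as these compounds go, is whether the loss follows the six-membered ring or its methyl group. A plain pyridin-3-yl or phenyl on the same carbonyl carbon would separate these two readings.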